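A few compounds are considered here, and "the series" means these few. Any claim that something is new, unique, unknown or untested is made for them only; others in the source may bear on it.

Working notes on the series. Compound 2 `Cc1cc(C(=O)NCc2cccnc2)nn1Cc1cc(Cl)ccc1OCc1ccccc1` gives 50.1 nM in an assay on CHO-K1 cells for displacement of a labelled ligand from prostaglandin E2 receptor EP1 subtype (Homo sapiens); on this read-out higher numbers stand for weaker inhibition and lower numbers for stronger inhibition; among the three numbers measured it stands second highest. Compound 1 `Cc1cc(C(=O)O)nn1C(C)c1cc(Cl)ccc1OCc1ccccc1`, the acid, gives 10 nM in this assay, a lower number than compound 2 and beyond the scatter. Compound 3 `Cc1cc(C(=O)NN2CCOCC2)nn1Cc1cc(Cl)ccc1OCC(C)C` gives 251 nM in this assay, a higher number than compound 2 and again beyond the scatter. Compound 4 `Cc1cc(NC(=O)c2ccccc2)nn1Cc1cc(Cl)ccc1OCc1ccccc1` is not yet measured; it differs from compound 2 by benzamido in place of ((pyridin-3-yl)methyl)carbamoyl on an aromatic carbon. Among the compounds with values here, no measured pair shows this kind of change, so the expectation rests only on compound 2 at 50.1 nM and the spread seen across compounds 1 to 3. A step toward a higher number is expected, a 2.0-fold higher number from compound 2 to compound 4 (0.30 log units; within the scatter), roughly at the edge of the scatter. For compound 4 the estimate is 100 nM, within 25 nM to 400 nM.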

Compound 4, half-maximal inhibitory concentration: 15.9 nM
Beside the measured number, compound 4's estimate is 6.3-fold (0.80 log units) above it, outside the stated range (below it).
By their numbers in this assay, from the lowest: compounds 1 and 4 (each within the scatter of the next); then compound 2; then compound 3.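

In this assay, within the data shown here, the first single-place comparison gives a 3.2-fold lower number from compound 2 to compound 4 (0.50 log units; beyond the scatter), where compound 4 carries benzamido and compound 2 carries ((pyridin-3-yl)methyl)carbamoyl. The aromatic carbon that bears these groups, next to the ring nitrogen, therefore need not carry a carbamoyl group to give a low number. Nothing available explains the step. The change swaps the ring and the linking atoms together, so the contribution of each stays unresolved. A pyridine-3-carboxamido group or a urea at this carbon would begin to separate them.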